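Adding bromine to the benzamide ring of compound 3

The source may hold more compounds than are shown below. What is called first, only, known or untested is meant among the compounds shown, and "the series" means these compounds.

Three compounds share the same core and were tested in a functional assay on MKN-74 cells (Homo sapiens) for antiproliferative activity, with a stated time of 24 h; on this read-out lower numbers stand for stronger inhibition and higher numbers for weaker inhibition. Compound 1 `NC(=O)c1c(NC(=O)c2ccc(C(F)(F)F)cc2)sc2c1CCN(Cc1ccc(Cl)cc1Cl)C2` gives 10900 nM. Compound 2 `NC(=O)c1c(NC(=O)c2ccccc2Cl)sc2c1CCN(C(=S)Nc1cccnc1)C2` gives 38600 nM. Compound 3 `NC(=O)c1c(NC(=O)c2ccccc2)sc2c1CCN(C(=S)Nc1ccccc1Cl)C2` gives 11800 nM. Among these three numbers, compound 3 holds the second highest; its value and that of compound 1 lie within the usual scatter of each other, so no order between them can be claimed, while compound 2 sits beyond the scatter at a clearly higher number, meaning weaker inhibition.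

The step to compound 4 `NC(=O)c1c(NC(=O)c2ccccc2Br)sc2c1CCN(C(=S)Nc1ccccc1Cl)C2` changes one place: bromo in place of hydrogen on an aromatic carbon, which reads as phenyl to 2-bromophenyl on the benzoyl group, ortho to a large group. Within the data shown here, no pair among the measured compounds shows this change alone, so there is no measured step to lean on. With nothing to point to a gain, the expected step from compound 3 to compound 4 is a 1.2-fold higher number from compound 3 to compound 4 (0.07 log units; within the scatter), which stays within the scatter. Compound 4 is therefore estimated at 14000 nM, in a range from 5000 nM to 40000 nM in this assay.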

Compound 4, half-maximal inhibitory concentration: 12900 nM
Beside the measured number, compound 4's estimate is 1.1-fold (0.04 log units) above it; the range from low to high includes it.
By their numbers in this assay, from the lowest: compounds 1, 3 and 4 (each within the scatter of the next); then compound 2.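

The step of a 1.1-fold higher number from compound 3 to compound 4 (0.04 log units; within the scatter) is the first change in a single place among these compounds in this assay and gives a direct reading of this position. On the benzoyl group, at an aromatic carbon ortho to a large group, bromo in place of hydrogen leaves the number within the scatter, so phenyl to 2-bromophenyl brings no clear gain or loss on this read-out. Nothing on hand explains why the number holds.

A single step at one position cannot show whether a methoxy group, an amine or a carboxylic acid in the same place would move the number beyond the scatter. It also leaves open whether bromo on other carbons of this ring, or the same change with a different group on the core, would read the same way.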